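Predicting a 3-Aminophenyl Analogue from Three Inactive Compounds

This account rests on a few compounds, and the source may have more. Where it says the series, first, only, none or still open, it means among the compounds named here.

Compound 1 `Fc1cccc(-c2nc(Nc3ccccc3)c3ccccc3n2)c1` in a functional assay on COLO 205 cells (Homo sapiens) for cytotoxicity, read by MTT assay, with a stated time of 48 h (a lower number here means a stronger inhibitor, a higher number a weaker inhibitor), gives > 50000 nM, which is a limit of the assay and not a number.
Compound 2 `Fc1cccc(-c2nc(Nc3ccccc3F)c3cc(F)ccc3n2)c1` in this assay gives > 50000 nM, also a limit.
Compound 3 `Oc1cccc(Nc2nc(-c3cccc(F)c3)nc3ccc(F)cc23)c1` in this assay gives > 50000 nM, again a limit.

Compound 2 therefore stands at the limit of this assay, and nothing measured separates it from the other two compounds, because of the limit of > 50000 nM in this assay, at which 3 of the 3 values shown sit. Compound 4 `Nc1cccc(Nc2nc(-c3cccc(F)c3)nc3ccc(F)cc23)c1` differs from compound 2 in one place: 3-aminophenyl in place of 2-fluorophenyl on a nitrogen on an aromatic ring. Among the measured compounds shown here, the only measured step at that same position is a step that the two limits leave unreadable from compound 2 to compound 3, and since both of its ends sit at the limit, its size and direction cannot be read. For the measured compounds named here, no measured step points to a gain in potency, and no measured step rules one out. With that in mind, compound 4 is expected to behave like compound 2, with an estimated value of 50000 nM, in a range from 15000 nM to 150000 nM. The step of a number no higher from compound 2 to compound 4 (the limit leaves the size open) is thus expected to be none beyond the scatter, most likely reported again as a limit.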

Compound 4, half-maximal inhibitory concentration: > 50000 nM
Compound 4: no number, only a limit; the forecaster's own chance of this, stated with the estimate: 80%; the middle value lies on the limit itself.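

In this assay compound 4 gives > 50000 nM, which is a limit of the assay and not a number. The steps to compound 4 from compound 2 and compound 3 cannot be read, because all of these results stop at the same point: the limit of > 50000 nM in this assay, at which 4 of the 4 values shown sit.

The compounds shown leave open how far apart they really lie, and whether any change to the shared core would give a value that can be read as a number.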